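The source may hold more compounds than are shown below. What is called first, only, known or untested is meant among the compounds shown, and "the series" means these compounds.

Compound 1 (`CCCOc1ccc(-c2cc(=O)c3c(o2)C(CC)(CC)C(=O)C(CC)=C3O)cc1`) gives > 50.5 uM as a limit of the assay
Compound 2 (`CCC1=C(O)c2c(oc(-c3cccc(C(F)(F)F)c3)cc2=O)C(CC)(CC)C1=O`) gives 35.7 uM as a number

In a functional assay on KB cells (Homo sapiens) for antiproliferative activity, read by sulforhodamine B assay, with a stated time of 3 days (a lower number here means that less compound is needed, a higher number that more compound is needed for the effect), both compounds were read. The entry for compound 1 is a limit, not a number (the limit of > 50.5 uM in this assay, at which 1 of the 2 values shown sits). Among the compounds with values here, compound 2 stands at 35.7 uM as the only actual number, with no second number to rank it against.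

Compound 3 (`CCC1=C(O)c2c(oc(-c3cccc(OC(F)(F)F)c3)cc2=O)C(CC)(CC)C1=O`) carries trifluoromethoxy in place of trifluoromethyl on an aromatic carbon, meta to a large group (trifluoromethoxy in place of trifluoromethyl on an aromatic carbon). Within the data shown here, no measured pair shows a step of this kind, so no change beyond the usual scatter is expected in this assay for this replacement. The only anchor for that expectation is compound 2 at 35.7 uM as measured. The estimated step is small (a 1.1-fold lower number from compound 2 to compound 3 (0.02 log units; within the scatter)). Compound 3 is expected at 34 uM with an estimated range from 16 uM to 60 uM in this assay.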

Compound 3, concentration for half-maximal effect: > 47.4 uM
Compound 3: no number, only a limit; the forecaster's own chance of this, stated with the estimate: 25%; middle value at least 1.3-fold (0.14 log units) from the limit.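

In this assay compound 3 gives a limit and not a number: the limit of > 47.4 uM in this assay, at which 1 of the 3 values shown sits.

Within the data shown here, this is the first measured pair for trifluoromethoxy in place of trifluoromethyl on this aromatic carbon, meta to a large group, and it reads as an at least 1.3-fold higher number from compound 2 to compound 3 (0.12 log units; that floor lies within the scatter). Among these compounds, only a floor is known for this step, so the pair does not tell whether the two groups differ at this position, and compound 2 remains the only compound of the three with an actual number.

From the compounds shown here alone, the size of the true step stays open, since the value of compound 3 lies somewhere beyond its limit. Also open, going by these compounds, is whether an amine or a carboxylic acid on this aromatic carbon would give a lower number than compound 2 does in this assay.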